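This account rests on a few compounds, and the source may have more. Where it says the series, first, only, none or still open, it means among the compounds named here.

Measured so far, all in an assay for binding affinity to dual specificity mitogen-activated protein kinase kinase 4 (Homo sapiens), read by KINOMEscan, tested at 100 nM; a lower number here means a stronger effect, a higher number a weaker effect of the compound at the concentration tested:

compound 1, `CCCS(=O)(=O)Nc1ccc(F)c(C(=O)c2n[nH]c3ncc(-c4cccc(Cl)c4)cc23)c1F`, gives 40%
compound 2, `CCCS(=O)(=O)Nc1ccc(F)c(C(=O)c2n[nH]c3ncc(-c4ccccc4N)cc23)c1F`, gives 23%
compound 3, `CCCS(=O)(=O)Nc1ccc(F)c(C(=O)c2n[nH]c3ncc(-c4ccc(N)cc4)cc23)c1F`, gives 0.1%

Compound 3 stands lowest of the three numbers in this assay; the nearest is compound 2, the furthest compound 1, and both gaps lie beyond the scatter. Compound 4, `CCCS(=O)(=O)Nc1ccc(F)c(C(=O)c2n[nH]c3ncc(-c4ccc(OC)cc4Cl)cc23)c1F`, differs from compound 3 as follows: 2-chloro-4-methoxyphenyl in place of 4-aminophenyl on an aromatic carbon.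

Within the data shown here, three steps bear on this change, all of which swap the substituent on the same aromatic carbon. From compound 1 to compound 3 the change was a number 39.9 percentage points lower from compound 1 to compound 3 (beyond the scatter); from compound 1 to compound 2 it was a number 17 percentage points lower from compound 1 to compound 2 (beyond the scatter); and from compound 2 to compound 3 it was a number 22.9 percentage points lower from compound 2 to compound 3 (beyond the scatter). The lowest number belongs to the 4-aminophenyl compound, while the 3-chlorophenyl compound gives the highest. Compound 4 removes the 4-aminophenyl and brings in a group that, like compound 1, carries a chlorine and no hydrogen-bond donor, so a rise back toward the number of compound 1 is expected, and in this assay compound 4 is expected to give a step of a number 39.9 percentage points higher from compound 3 to compound 4 (beyond the scatter). Nothing measured shows the effect of the methoxy, so the range is wide. Compound 4 is estimated at 40%, with a range from 15% to 75%.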

Compound 4, a percentage reported as activity, at one concentration (the size of the read-out at that concentration, not a potency): 5.3%
Compound 4: middle estimate off by 34.7 percentage points, on the high side; measured number below the stated range.
By their numbers in this assay, from the lowest: compounds 3 and 4 (each within the scatter of the next); then compound 2; then compound 1.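

In this assay, 2-chloro-4-methoxyphenyl in place of 4-aminophenyl gives a number 5.2 percentage points higher from compound 3 to compound 4 (within the scatter) even though the entering group has 0 hydrogen-bond donors, so a donor on this aromatic ring is not needed for a low number at this position. Chlorine on the ring does not by itself keep the number high either, since compound 1 and compound 4 both carry chlorine and no donor, yet the change gives a number 34.7 percentage points lower from compound 1 to compound 4 (beyond the scatter), while the step from the 2-aminophenyl compound is a number 17.7 percentage points lower from compound 2 to compound 4 (beyond the scatter). No measurement at hand explains why these groups differ.

Going by these compounds, it remains open whether the methoxy or the chlorine of compound 4 accounts for its low number, which a plain 4-methoxyphenyl group would help to separate. On these data alone, how a 4-hydroxyphenyl group or a carboxylic acid on the same ring would read in this assay also remains open.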